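The compounds below may be only part of what the source reports. "The series", "measured", "known", "first", "only" and "open" are said of these compounds alone.

Measured compounds:
compound 1, `CC(C)(C)c1ccc(C(=O)NCc2c(F)cc(NS(C)(=O)=O)cc2F)cc1`, gives 9.3 mL.min-1.g-1
compound 2, `CS(=O)(=O)Nc1ccc(CNC(=O)c2ccc(N3CCCCC3)cc2)c(Cl)c1`, gives 20 mL.min-1.g-1

Both numbers come from an ADME assay on microsomes from liver (Rattus norvegicus, strain Sprague-Dawley) for metabolic stability, read by HPLC, using NADPH, with stated times of 5 min and 60 min, tested at 10 uM; on this read-out higher numbers stand for fast clearance and lower numbers for slow clearance. On these two numbers compound 2 stands highest; the nearest is compound 1, whose number is lower by a distance that lies beyond the usual scatter. Compound 3, `CS(=O)(=O)Nc1ccc(CNC(=O)c2ccc(S(F)(F)(F)(F)F)cc2)c(Cl)c1`, has not yet been measured. It differs from compound 2 at one place: a group of 6 heavy atoms (5 fluorine, 1 sulfur; no ring) in place of a group of 6 heavy atoms (5 carbon, 1 nitrogen; one six-membered non-aromatic ring with 1 hetero atom), on an aromatic carbon. The change sits on an aromatic carbon of a six-membered aromatic ring of carbon only, para to a large group. Among the compounds with values here, no pair of measured compounds differs in a single place, so no measured step can guide the expectation directly; only the two values above and the nature of the change are available. In this assay the step is expected to be a 2.9-fold lower number from compound 2 to compound 3 (0.46 log units; beyond the scatter), a drop that goes beyond the scatter. Compound 3 is accordingly estimated at 7 mL.min-1.g-1, with a range from 3 mL.min-1.g-1 to 16 mL.min-1.g-1.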

Compound 3, intrinsic clearance in microsomes: 9.8 mL.min-1.g-1
Beside the measured number, compound 3's estimate is 1.4-fold (0.15 log units) below it, and the stated range covers the measured number.
By their numbers in this assay, from the lowest: compounds 1 and 3 (each within the scatter of the next); then compound 2.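

In this assay, the aromatic carbon para to a large group proves to be a place where a single change moves the read-out: a 2.0-fold lower number from compound 2 to compound 3 (0.31 log units; beyond the scatter), when the group of five fluorine atoms and one sulfur atom enters in place of piperidin-1-yl. The step is modest, but it shows that a group with no ring and no hydrogen-bond acceptor can stand here with a lower number than piperidin-1-yl gives. No measurement is available that bears on what lies behind this step.

A single step cannot separate the loss of the ring or of its nitrogen from the effect of the entering group itself. On these data alone, how a morpholin-4-yl or a trifluoromethyl group would read at this place remains open, as does whether the same exchange would give a similar step on the core of compound 1.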